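The source may report more compounds than this note shows. Statements on the series, on what has been measured and on what is new or still open speak of the compounds shown alone.

Among the compounds with values here, in an ADME assay on WI-38 cells (Homo sapiens) for cytotoxicity, read by MTT assay, with a stated time of 72 h (on this read-out lower numbers stand for stronger inhibition and higher numbers for weaker inhibition), compound 2 `O=C(CCc1cccc2c1B(O)OC2)Nc1cccc(-c2cccc(Cl)c2)c1` gives 58000 nM, the higher of the two numbers measured so far, while compound 1 `O=C(CCc1cccc2c1B(O)OC2)Nc1cccc(-c2ccc(F)cc2)c1` gives 4100 nM. Compound 3 `O=C(CCc1cccc2c1B(O)OC2)Nc1cccc(-c2ccc(Cl)cc2)c1` brings (4-chlorophenyl in place of 3-chlorophenyl on an aromatic carbon), that is, 4-chlorophenyl in place of 3-chlorophenyl on an aromatic carbon. Within the data shown here, only one measured step bears on this, a 14-fold higher number from compound 1 to compound 2 (1.15 log units; beyond the scatter), a large one that came with 3-chlorophenyl in place of 4-fluorophenyl. The group 4-chlorophenyl looks closer to the 4-fluorophenyl of compound 1, which gives 4100 nM. Part of that step is expected to reverse. The estimated step is a 4.1-fold lower number from compound 2 to compound 3 (0.62 log units; beyond the scatter). For compound 3 the expected value is 14000 nM, with a range from 4000 nM to 50000 nM.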

Compound 3, half-maximal inhibitory concentration: 9800 nM
Compound 3: the middle estimate sits 1.4-fold (0.15 log units) above what was measured, within the range that was stated.
By their numbers in this assay, from the lowest: compound 1; then compound 3; then compound 2.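

In this assay, the same chlorine on the same ring gives quite different numbers: 4-chlorophenyl in place of 3-chlorophenyl gives a 5.9-fold lower number from compound 2 to compound 3 (0.77 log units; beyond the scatter) and so shows that where the atom sits matters, not only which atom it is. With the place kept, chloro in place of fluoro gives a 2.4-fold higher number from compound 1 to compound 3 (0.38 log units; beyond the scatter) and is the smaller of these two steps. Nothing available gives a reason for either step. Still open, going by these compounds, is how 3-fluorophenyl would compare, and whether an amine or a carboxylic acid in place of the halogen would follow the same order.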